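A few compounds are considered here, and "the series" means these few. Any claim that something is new, unique, unknown or untested is made for them only; others in the source may bear on it.

Measured so far:
compound 1, `COc1ccc2nc3c(nc2c1)O[C@H]1CN(C(=O)[C@H](C(C)(C)C)NC(=O)O[C@@H]2C[C@H]2CCCCC3)[C@H](C(=O)N[C@]2(C(=O)NS(=O)(=O)C3(C)CC3)C[C@H]2C(F)F)[C@@H]1C`, 1.3 h;
compound 2, `CC[C@@H]1[C@@H]2CN(C(=O)[C@H](C(C)(C)C)NC(=O)O[C@@H]3C[C@H]3CCCCCc3nc4ccc(OC)cc4nc3O2)[C@@H]1C(=O)N[C@]1(C(=O)NS(=O)(=O)C2(C)CC2)C[C@H]1C(F)F`, 1.4 h;
compound 3, `C=C[C@@H]1C[C@]1(NC(=O)[C@@H]1[C@H](CC)[C@@H]2CN1C(=O)[C@H](C(C)(C)C)NC(=O)O[C@@H]1C[C@H]1CCCCCc1nc3ccc(OC)cc3nc1O2)C(=O)NS(=O)(=O)C1CC1`, 2.2 h.

In an ADME assay (Rattus norvegicus) for metabolic stability (on this read-out lower numbers stand for a shorter-lived compound and higher numbers for a longer-lived compound), compound 3 holds the highest of the three numbers; compound 2 sits nearest to it and compound 1 furthest, yet both gaps are within the scatter, so no order among the three can be claimed. Among the compounds with values here, the one measured step, a 1.1-fold higher number from compound 1 to compound 2 (0.03 log units; within the scatter), concerns methyl in place of hydrogen on a saturated chain carbon bound to a saturated ring carbon and does not touch the groups that change here.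

Compound 4, `CC[C@@H]1[C@@H]2CN(C(=O)[C@H](C(C)(C)C)NC(=O)O[C@@H]3C[C@H]3CCCCCc3nc4ccc(OC)cc4nc3O2)[C@@H]1C(=O)N[C@]1(C(=O)NS(=O)(=O)C2CC2)C[C@H]1C(F)F`, is to be measured in this assay. It differs from compound 3 by difluoromethyl in place of vinyl on a saturated ring carbon. Within the data shown here, no measured step covers this exchange. Compounds 1 and 2 already carry the difluoromethyl group and both show numbers that stay within the scatter of compound 3, so the data give no ground for a step beyond the scatter in either direction. Compound 4 is therefore expected to give about 1.6 h, within 0.9 h to 2.8 h. The expected step of a 1.4-fold lower number from compound 3 to compound 4 (0.14 log units; within the scatter) is estimated to be small, leaning slightly toward a shorter-lived compound.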

Compound 4, half-life in the Rattus norvegicus assay: 0.8 h
Estimate against measurement, compound 4: 2.0-fold (0.30 log units) above, and the stated range ends above it.
By their numbers in the Rattus norvegicus assay, from the lowest: compounds 4, 1, 2 and 3 (each within the scatter of the next, the first and the last beyond it).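

Within the data shown here, in the Rattus norvegicus assay, the exchange of vinyl for difluoromethyl on a saturated ring carbon of the three-membered ring now has a direct reading, and it gives the only step in this set that lies beyond the scatter: a 2.8-fold lower number from compound 3 to compound 4 (0.44 log units; beyond the scatter). Removing the methyl on the neighbouring sulfonyl-bearing ring carbon is a different matter, since a 1.8-fold lower number from compound 2 to compound 4 (0.24 log units; within the scatter) stays within the scatter and so shows no change that can be read. In a physicochemical assay for lipophilicity (a higher number here means a more lipophilic compound, a lower number a more polar compound), compound 3 gives 4.1 and compound 4 gives 3.5, so the shorter half-life of compound 4 does not go along with a higher distribution coefficient: the measured distribution coefficient of compound 3, 4.1, and of compound 4, 3.5, a number 0.60 log units lower (beyond the scatter)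

Only one pair carries this exchange, so the compounds shown leave open whether the same step would appear with the methyl-bearing sulfonyl group of compounds 1 and 2, or with a different core. They also leave open whether the step follows the fluorine atoms or the loss of the double bond outside aromatic rings, which an ethyl or a trifluoromethyl group on this ring carbon would help to separate.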